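This account rests on a few compounds, and the source may have more. Where it says the series, first, only, none or still open, it means among the compounds named here.

Measured so far in an assay on CHO cells for antagonist activity at transient receptor potential cation channel subfamily V member 1 (Homo sapiens), read by FLIPR; on this read-out lower numbers stand for stronger inhibition and higher numbers for weaker inhibition:
compound 1 `CCC(C(=O)NCc1ccc(C(F)(F)F)nc1N1CCC(C)CC1)c1ccc(NS(C)(=O)=O)c(F)c1` gives 1.6 nM
compound 2 `CC1CCN(c2nc(C(F)(F)F)ccc2CNC(=O)C(C)(C)c2ccc(NS(C)(=O)=O)c(F)c2)CC1` gives 49 nM
compound 3 `CC(C)(C(=O)NCc1ccc(C(F)(F)F)nc1SC1CCCCC1)c1ccc(NS(C)(=O)=O)c(F)c1` gives 65.7 nM

Compound 2 holds the second highest of the three numbers. Its nearest neighbour is compound 3, where the change on the shared core, a 1.3-fold higher number from compound 2 to compound 3 (0.13 log units; within the scatter), stays within the scatter. Compound 1 stands far off with the lowest number of the set, but compound 1 and compound 2 differ in two places on the saturated chain carbon, so their values alone do not isolate the change considered here.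

Compound 4 `CCC(C)(C(=O)NCc1ccc(C(F)(F)F)nc1N1CCC(C)CC1)c1ccc(NS(C)(=O)=O)c(F)c1` is not yet measured. It arises from compound 2 by methyl in place of hydrogen on a saturated chain carbon, two bonds along the chain from an aromatic carbon and a carbonyl carbon; seen one bond further out, a methyl becomes an ethyl.

Within the data shown here, no measured step alters this chain carbon in a single move, so nothing directly bears on the step from compound 2 to compound 4. Compound 1 carries an ethyl on that carbon and gives a low number, which gives some reason to expect that an ethyl is tolerated, but compound 1 also differs in the second group on that carbon, so the expectation stays loose. A modest movement toward a lower number, a 1.6-fold lower number from compound 2 to compound 4 (0.21 log units; within the scatter), is expected, with a wide range.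

Compound 4 is estimated at 30 nM, between 8 nM and 120 nM.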

Compound 4, inhibition constant: 124 nM
The estimate for compound 4 lay 4.1-fold (0.62 log units) below the measured number, outside the stated range (above it).
By their numbers in this assay, from the lowest: compound 1; then compounds 2, 3 and 4 (each within the scatter of the next, the first and the last beyond it).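

In this assay this saturated chain carbon can now be read in single moves, and both moves add a methyl in place of hydrogen. On the carbon bearing a methyl, the change gives a 2.5-fold higher number from compound 2 to compound 4 (0.40 log units; beyond the scatter) and, seen one bond further out, amounts to methyl becoming ethyl; on the carbon bearing an ethyl, it gives a 78-fold higher number from compound 1 to compound 4 (1.89 log units; beyond the scatter) and removes the last hydrogen there. Among these compounds an ethyl on this carbon therefore does not by itself go with a low number: the low number of compound 1 is lost once that hydrogen is replaced, and the ethyl of compound 4 gives no gain over the methyl of compound 2. No measurement on hand accounts for either step.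

Still open, going by these compounds, is how a propyl, a cyclopropyl, a hydroxyl or a fluorine on this carbon would read against the hydrogen of compound 1. Also open, on these data alone, is whether the same steps hold with cyclohexylsulfanyl, as in compound 3, in place of 4-methylpiperidin-1-yl on the shared core.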